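A Ring Exchange on the Amide-Type Nitrogen

The compounds below may be only part of what the source reports. "The series", "measured", "known", "first", "only" and "open" are said of these compounds alone.

Of the compounds shown here, two sharing one core have been tested in a functional assay on Shh Light II cells (Mus musculus) for inhibition, read by a luciferase reporter; a lower number here means a stronger inhibitor, a higher number a weaker inhibitor. Compound 1 `O=C(Nc1ccccc1Cl)N1CCN(c2nc(-c3ccc4ccccc4n3)no2)CC1` gives 140 nM in this assay. Compound 2 `O=C(NC1CC[S+]([O-])CC1)N1CCC(c2nc(-c3ccc4ccccc4n3)no2)CC1` gives 850 nM in this assay, the higher of the two numbers, and the gap to compound 1 lies beyond the usual scatter. Since these two structures differ in more than one place, nothing is said here about which change carries that gap.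

Compound 3 `O=C(NC1CCOCC1)N1CCC(c2nc(-c3ccc4ccccc4n3)no2)CC1` has not been measured. It differs from compound 2 in a single place: a group of 6 heavy atoms (5 carbon, 1 oxygen; one six-membered non-aromatic ring with 1 hetero atom) in place of a group of 7 heavy atoms (5 carbon, 1 oxygen, 1 sulfur; one six-membered non-aromatic ring with 1 hetero atom), on an amide-type nitrogen. The ring that enters keeps the six-membered non-aromatic shape, the one hetero atom and the single hydrogen-bond acceptor; the sulfur atom is lost. Going by the values given here, no measured pair speaks to this exchange, so the step is expected to stay within the usual scatter, leaning if anything toward a lower number, with a 1.2-fold lower number from compound 2 to compound 3 (0.08 log units; within the scatter) as the expected step. Compound 3 is estimated at 700 nM, with a range from 300 nM to 1700 nM.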

Compound 3, half-maximal inhibitory concentration: 480 nM
Beside the measured number, compound 3's estimate is 1.5-fold (0.16 log units) above it; the measured number falls inside the stated range.
By their numbers in this assay, from the lowest: compound 1; then compounds 3 and 2 (each within the scatter of the next).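

In this assay, the exchange of the sulfur-bearing ring for oxan-4-yl on the amide-type nitrogen gives a 1.8-fold lower number from compound 2 to compound 3 (0.25 log units; within the scatter), the only comparison among these compounds that differs in one place. It shows that, for this pair, losing the sulfur atom while keeping the six-membered non-aromatic ring, its one hetero atom and its single hydrogen-bond acceptor leaves the number within the scatter, so the exchange cannot be said to change inhibition in this assay. No accompanying data bear on this result.

The compounds shown leave open how an open-chain ether, a cyclohexyl ring, an amine or a carboxylic acid would behave on this nitrogen. They also leave open which change separates compound 1 from compound 2 and compound 3, since it differs from each in more than one place.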